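The source may hold more compounds than are shown below. What is called first, only, known or untested is meant among the compounds shown, and "the series" means these compounds.

Measured compounds in a functional assay on PC-3 cells (Homo sapiens) for antiproliferative activity, read by MTT assay, with a stated time of 48 h; on this read-out lower numbers stand for stronger inhibition and higher numbers for weaker inhibition:
- compound 1 `O=C(/C=C\Nc1ccc(Cl)cc1)c1cn(-c2ccccc2)nc1-c1ccccc1`, with 5200 nM
- compound 2 `O=C(/C=C\Nc1ccc(Cl)cc1)c1cn(-c2ccccc2)nc1-c1ccc(Cl)cc1`, with 3890 nM
- compound 3 `O=C(/C=C\Nc1ccc(C(F)(F)F)cc1)c1cn(-c2ccccc2)nc1-c1ccc(Cl)cc1`, which reaches only the limit > 50000 nM of this assay

Compound 2 gives the lowest of the two real numbers, but its nearest neighbour compound 1 sits within the scatter, so the two cannot be told apart. Compound 4 `COc1ccc(-c2nn(-c3ccccc3)cc2C(=O)/C=C\Nc2ccc(Cl)cc2)cc1` differs from compound 2 by methoxy in place of chloro on an aromatic carbon. For the measured compounds named here, two measured steps bear on this. The first, a 1.3-fold lower number from compound 1 to compound 2 (0.13 log units; within the scatter), shows that changing the substituent on the 4-chlorophenyl scarcely moved the number. The second, an at least 12-fold higher number from compound 2 to compound 3 (1.10 log units; beyond the scatter), shows that a swap on an aromatic carbon can push a compound out to the limit of > 50000 nM in this assay, at which 1 of the 3 values shown sits, a large step. Since the methoxy replaces the chloro that made no visible difference against hydrogen, a small step is expected, with no clear direction: a 1.2-fold higher number from compound 2 to compound 4 (0.06 log units; within the scatter). Compound 4 is therefore estimated at 4500 nM, within a range from 1800 nM to 12000 nM.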

Compound 4, half-maximal inhibitory concentration: 3890 nM
Estimate against measurement, compound 4: 1.2-fold (0.06 log units) above; measured number inside the range.
By their numbers in this assay, from the lowest: compounds 2, 4 and 1 (each within the scatter of the next). At a limit, above all of these: compound 3.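

In this assay, methoxy in place of chloro gives no change at the digits printed from compound 2 to compound 4 (within the scatter), and methoxy in place of hydrogen gives a 1.3-fold lower number from compound 1 to compound 4 (0.13 log units; within the scatter). Hydrogen, chloro and methoxy on this aromatic carbon therefore cannot be told apart, even though methoxy brings a hydrogen-bond acceptor that chloro lacks. The large change seen with compound 3 involves the other chloro of compound 2, on a different aromatic ring, so it says nothing about this position, and compound 3 remains the only compound at a limit: the limit of > 50000 nM in this assay, at which 1 of the 4 values shown sits.

Three groups are too few to show that this position tolerates any change. On these data alone, whether an amine, a carboxylic acid or a longer chain here would also leave the number within the scatter stays open.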